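The source may hold more compounds than are shown below. What is called first, only, known or untested is meant among the compounds shown, and "the series" means these compounds.

Compound 1 `COc1ccc(-c2cc(C(=O)/C=C/c3ccc(C)cc3)nc3cc(-c4ccccc4)nn23)cc1OC`: 22600 nM
Compound 2 `COc1ccc(-c2cc(/C=C/C(=O)c3ccc(C)cc3)nc3cc(-c4ccccc4)nn23)cc1OC`: 19800 nM
Compound 3 `COc1ccc(C(=O)/C=C/c2cc(-c3ccc(OC)c(OC)c3)n3nc(-c4ccccc4)cc3n2)cc1OC`: 2600 nM

In a functional assay on MDA-MB-231 cells (Homo sapiens) for antiproliferative activity, read by MTT assay, with a stated time of 24 h (a lower number here means a stronger inhibitor, a higher number a weaker inhibitor), compound 3 gives the lowest of the three numbers; the step of a 7.6-fold lower number from compound 2 to compound 3 (0.88 log units; beyond the scatter) separates it from compound 2, and compound 1 lies furthest off. Compound 4 `COc1ccc(-c2cc(/C=C/C(=O)c3ccccc3)nc3cc(-c4ccccc4)nn23)cc1OC` differs from compound 3 by phenyl in place of 3,4-dimethoxyphenyl on a carbonyl carbon. Within the data shown here, the only measured step at this carbonyl carbon is a 7.6-fold lower number from compound 2 to compound 3 (0.88 log units; beyond the scatter), where the 3,4-dimethoxyphenyl arrived in place of 4-methylphenyl; the step of a 1.1-fold lower number from compound 1 to compound 2 (0.06 log units; within the scatter) changed only the orientation of the linker and stayed within the scatter. Among the measured compounds shown here, no measured pair compares phenyl with 4-methylphenyl. Compound 4 is therefore expected to give a higher number than compound 3, by a modest step of a 4.6-fold higher number from compound 3 to compound 4 (0.66 log units; beyond the scatter). The estimate for compound 4 is 12000 nM, expected between 4000 nM and 35000 nM.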

Compound 4, half-maximal inhibitory concentration: 11800 nM
Compound 4: middle estimate off by 1.0-fold (0.01 log units), on the high side; the range from low to high includes it.
By their numbers in this assay, from the lowest: compound 3; then compounds 4, 2 and 1 (each within the scatter of the next).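

In this assay the exchange of 3,4-dimethoxyphenyl for phenyl on the carbonyl carbon now stands as a step of its own, a 4.5-fold higher number from compound 3 to compound 4 (0.66 log units; beyond the scatter), and it lies beyond the scatter. Removing the methyl gives only a 1.7-fold lower number from compound 2 to compound 4 (0.22 log units; within the scatter), and reversing the linker as well gives a 1.9-fold lower number from compound 1 to compound 4 (0.28 log units; within the scatter), so among these compounds only the 3,4-dimethoxyphenyl of compound 3 sets one apart. Nothing available explains the effect of that group. As far as these compounds go, whether a single methoxy, an amine or a carboxylic acid on this phenyl would keep the lower number stays open.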